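The compounds below may be only part of what the source reports. "The series", "measured", "known", "first", "only" and "open" are said of these compounds alone.

In a functional assay on SW982 cells (Homo sapiens) for inhibition, read by MTT assay, with a stated time of 72 h (a higher number here means a weaker inhibitor, a lower number a stronger inhibitor), compound 1 (`COc1cc(OC)c(OC)cc1/C=C/C(=O)c1ccc(Cl)cc1`), which carries a chloro group, gives 58500 nM. Compound 2 (`COc1cc(OC)c(OC)cc1/C=C/C(=O)c1ccc(-c2c[nH]cn2)cc1`) gives > 150000 nM, and this is a limit of the assay, not a number. All that can be said of compound 2 is that it stands at this limit, with no measured value to start from.

Compound 3 (`COc1cc(OC)c(OC)cc1/C=C/C(=O)c1ccc(F)cc1`) has fluoro in place of 1H-imidazol-4-yl on an aromatic carbon, para to a large group: fluoro in place of 1H-imidazol-4-yl on an aromatic carbon.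

Going by the values given here, one measured step bears on this change. Going by these compounds, it put 1H-imidazol-4-yl in place of chloro and gave an at least 2.5-fold higher number from compound 1 to compound 2 (0.40 log units; beyond the scatter), which lies beyond the scatter, though its full size stays unknown. The new change runs the other way, returning a single halogen to that carbon, with compound 1 at 58500 nM as the nearest guide. I therefore expect an at least 2.1-fold lower number from compound 2 to compound 3 (0.33 log units; beyond the scatter) in this assay, a move towards a lower number and a stronger inhibitor. Compound 3 is estimated at 70000 nM, with an expected range from 30000 nM to 140000 nM.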

Compound 3, half-maximal inhibitory concentration: 32500 nM
Compound 3: middle estimate off by 2.2-fold (0.33 log units), on the high side, within the range that was stated.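

In this assay, fluoro in place of 1H-imidazol-4-yl on this aromatic carbon gives an at least 4.6-fold lower number from compound 2 to compound 3 (0.66 log units; beyond the scatter). The poor result of compound 2 therefore now stands against two halogens, not chloro alone. Fluoro in place of chloro gives a 1.8-fold lower number from compound 1 to compound 3 (0.26 log units; within the scatter), which lies within the scatter, so these two halogens cannot be told apart at this position, and on this carbon the clear divide so far runs between either halogen and the five-membered ring. Compound 2 remains a limit of the assay, not a number, so the full size of both steps to it stays unknown: the limit of > 150000 nM in this assay, at which 1 of the 3 values shown sits.

These three compounds cannot show whether the drop in compound 2 belongs to the 1H-imidazol-4-yl ring in particular or would come with any group larger than a single halogen, and a plain phenyl ring, an amine or a methoxy group on the same carbon would help to separate those readings. Also open, going by these compounds, is whether any group here can bring the number far below that of the halogens, which so far give the lowest values shown.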